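This account rests on a few compounds, and the source may have more. Where it says the series, first, only, none or still open, it means among the compounds named here.

Working notes on the series.

Compound 1 `c1ccc(OCCCCOc2cccc(-c3cc4cc(C5=NCCN5)ccc4o3)c2)cc1` and compound 2 `c1ccc(OCCCCCOc2cccc(-c3cc4cc(C5=NCCN5)ccc4o3)c2)cc1` share a core and differ in one place: phenoxymethyl in place of phenoxy on a saturated chain carbon, four bonds along the chain from an oxygen on an aromatic ring. In an ADME assay on L6 cells (Rattus norvegicus) for cytotoxicity, read by resazurin assay, with a stated time of 70 h (a lower number here means a stronger inhibitor, a higher number a weaker inhibitor), compound 1 gives 9500 nM and compound 2 gives 2600 nM, so that a 3.7-fold lower number from compound 1 to compound 2 (0.56 log units; beyond the scatter).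

Compound 3 `N=C(N)c1ccc2oc(-c3ccc(OCCCOc4ccccc4)cc3)cc2c1` carries a different core; how it differs from the core of compound 1 is not broken down here. In this assay compound 3 gives 7300 nM, a number within the scatter of compound 1 and beyond the scatter of compound 2.

Compound 4 `N=C(N)c1ccc2oc(-c3ccc(OCCCCOc4ccccc4)cc3)cc2c1` is not yet measured. It differs from compound 3 as follows: phenoxymethyl in place of phenoxy on a saturated chain carbon, three bonds along the chain from an oxygen on an aromatic ring. This is the same kind of change as that from compound 1 to compound 2, though there the place was four bonds along the chain from an oxygen on an aromatic ring and here it is three.

Among the measured compounds shown here, for compound 4 the step of a 2.9-fold lower number from compound 3 to compound 4 (0.47 log units; beyond the scatter) is expected, beside a 3.7-fold lower number from compound 1 to compound 2 (0.56 log units; beyond the scatter), because the step of a 3.7-fold lower number from compound 1 to compound 2 (0.56 log units; beyond the scatter) is the only measured instance of this kind of change, and the core differs. Compound 4 is estimated at 2500 nM, between 1000 nM and 7000 nM.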

Compound 4, half-maximal inhibitory concentration: 1300 nM
Compound 4: the middle estimate sits 1.9-fold (0.28 log units) above what was measured, and the stated range covers the measured number.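

In this assay, replacing phenoxy with phenoxymethyl on a saturated chain carbon, three bonds along the chain from an oxygen on an aromatic ring, gives a 5.6-fold lower number from compound 3 to compound 4 (0.75 log units; beyond the scatter) on the core of compound 3. Set beside the earlier step, the change carries across the two cores in direction, and the sizes are not told apart: the same change on two cores in this assay, a 3.7-fold lower number (0.56 log units; beyond the scatter) from compound 1 to compound 2 and a 5.6-fold lower number (0.75 log units; beyond the scatter) from compound 3 to compound 4, 1.5-fold (0.19 log units) apart, within the scatter of two such steps. Among the compounds shown here, this rests on only two pairs, with the change at a different place along the chain in each, so it does not show that the step would hold on any other core, nor does it give a reason for the step.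

Still open, from the compounds shown here alone, is whether 2-phenoxyethyl in place of phenoxymethyl, or a longer chain still, would lower the number further on either core. Also open, going by these compounds, is how the series would read in this assay with an amine or a carboxylic acid in place of the phenoxy group.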